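The compounds below may be only part of what the source reports. "The series", "measured", "known", "first", "only" and "open" are said of these compounds alone.

Of the compounds shown here, three sharing one core have been measured in an assay on THP-1 cells for displacement of a labelled ligand from C-C chemokine receptor type 1 (Homo sapiens); a higher number here means a weaker inhibitor, a lower number a stronger inhibitor. Compound 2 `Cc1ccccc1CCC(=O)N[C@@H](C(=O)N1CCC(c2ccc(Cl)cc2)CC1)C(C)C` gives 19 nM, the lowest of the three numbers and thus the strongest inhibitor among them. Compound 1 `CC(C)C(NS(=O)(=O)Cc1ccccc1)C(=O)N1CCC(c2ccc(Cl)cc2)CC1` gives 303 nM, and compound 3 `CC(C)C(NC(=O)OCc1ccccc1)C(=O)N1CCC(c2ccc(Cl)cc2)CC1` gives 1080 nM. For the measured compounds named here, the only step between two compounds that differ in a single place is a 3.6-fold higher number from compound 1 to compound 3 (0.55 log units; beyond the scatter); here the benzyl ring stays and only its link to the amine nitrogen changes, and the number shifts by a modest amount. Compound 4 `CC(C)CC(=O)N[C@@H](C(=O)N1CCC(c2ccc(Cl)cc2)CC1)C(C)C` now differs from compound 2 by isopropyl in place of 2-methylbenzyl on a saturated chain carbon bound to a carbonyl carbon. Going by the values given here, no measured step removes the six-membered aromatic ring from this part of the molecule, so the earlier step speaks only indirectly to the change: it shows that this region is sensitive to what sits there, and the wide gap between compound 2 and the other two compounds points the same way. Compound 4 is therefore expected to be a weaker inhibitor than compound 2 in this assay, with an estimated value of 150 nM and a likely range from 40 nM to 600 nM. The expected size of the change is a 7.9-fold higher number from compound 2 to compound 4 (0.90 log units; beyond the scatter).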

Compound 4, half-maximal inhibitory concentration: 32 nM
Beside the measured number, compound 4's estimate is 4.7-fold (0.67 log units) above it; the whole stated range lies above it.
By their numbers in this assay, from the lowest: compounds 2 and 4 (each within the scatter of the next); then compound 1; then compound 3.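

In this assay, isopropyl in place of 2-methylbenzyl on a saturated chain carbon bound to a carbonyl carbon gives a 1.7-fold higher number from compound 2 to compound 4 (0.23 log units; within the scatter) and so leaves the two compounds indistinguishable. This is something the earlier step could not show: that step kept the benzyl ring and changed only its link to the amine nitrogen, whereas here the six-membered aromatic ring goes altogether, and the group at this place shrinks from 8 heavy atoms to 3 with no measurable loss of inhibition. For this pair, then, the aromatic ring is not needed for a low number in this assay, and nothing measured here accounts for that result.

The compounds shown leave open how far this tolerance extends, since a single pair cannot say whether a much shorter group such as methyl, or a longer unbranched chain such as n-hexyl, would also keep the number within the scatter of compound 2. They also leave open what an amine or a carboxylic acid at this place would do, as both groups in this pair consist of carbon only.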